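The compounds below may be only part of what the source reports. "The series", "measured", "known", "first", "only" and "open" are said of these compounds alone.

Measured so far in a functional assay on SF-268 cells (Homo sapiens) for inhibition, read by sulforhodamine B assay, with a stated time of 48 h, tested at 10 uM; on this read-out lower numbers stand for less inhibition and higher numbers for more inhibition at the one concentration tested (going by the name of the read-out):
compound 1 `O=Cc1ccc(-c2cn3ccnc3c(-c3ccc4ncn(C5CCCCC5)c4c3)n2)cc1` — 27.1%
compound 2 `COc1ccccc1-c1cn2ccnc2c(-c2ccc3ncn(C4CCCCC4)c3c2)n1` — 8.04%
compound 3 `Fc1ccccc1-c1cn2ccnc2c(-c2ccc3ncn(C4CCCCC4)c3c2)n1` — 6.04%

Compound 3 gives the lowest number of the three in this assay. Its nearest neighbour is compound 2, and that step, a number 2 percentage points lower from compound 2 to compound 3 (within the scatter), stays within the scatter, so the two cannot be ordered. Against compound 1 the gap is a number 21.1 percentage points lower from compound 1 to compound 3 (beyond the scatter), beyond the scatter, and it is matched by a number 19.1 percentage points lower from compound 1 to compound 2 (beyond the scatter).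

Compound 4 `FC(F)(F)c1cccc(-c2cn3ccnc3c(-c3ccc4ncn(C5CCCCC5)c4c3)n2)c1` is not yet measured. Its change from compound 3: 3-(trifluoromethyl)phenyl in place of 2-fluorophenyl on an aromatic carbon

Steps that bear on it: the one exchange of a substituent on the same ring, a number 2 percentage points lower from compound 2 to compound 3 (within the scatter), was within the scatter; the two exchanges of the whole 4-formylphenyl, a number 19.1 percentage points lower from compound 1 to compound 2 (beyond the scatter) and a number 21.1 percentage points lower from compound 1 to compound 3 (beyond the scatter), were modest and both downward, and both ran from the highest number of the set. Compound 3 already sits at the low end, so there is little room for a further drop of that kind. Among the measured compounds shown here, no measured step resembles the exchange of fluoro for trifluoromethyl. The expected step of a number 2 percentage points higher from compound 3 to compound 4 (within the scatter) is therefore none beyond the scatter. Compound 4 is estimated at 8% in this assay, within 0% to 22%.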

Compound 4, a percentage reported as inhibition, at one concentration (the size of the read-out at that concentration, not a potency): 3.3%
Beside the measured number, compound 4's estimate is 4.7 percentage points above it; low and high end bracket the measured number.
By their numbers in this assay, from the lowest: compounds 4, 3 and 2 (each within the scatter of the next); then compound 1.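

In this assay, trifluoromethyl on the phenyl ring brings no separation from the ring-fluoro or ring-methoxy analogues at this position on the core: a number 2.7 percentage points lower from compound 3 to compound 4 (within the scatter), and a number 4.7 percentage points lower from compound 2 to compound 4 (within the scatter). The 2-methoxyphenyl, 2-fluorophenyl and 3-(trifluoromethyl)phenyl groups therefore form one set that cannot be ordered, while the 4-formylphenyl alone stands apart, with a number 23.8 percentage points lower from compound 1 to compound 4 (beyond the scatter). Nothing at hand accounts for that separation.

From the compounds shown here alone, it remains open whether the higher number of compound 1 belongs to the formyl group itself or to its place on the phenyl ring. Going by these compounds, it is also open whether a carboxylic acid or an amine in place of the formyl group would hold or raise the number.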